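Dihalophenyl versus methoxyphenyl on the carbonyl carbon

The source may report more compounds than this note shows. Statements on the series, on what has been measured and on what is new or still open speak of the compounds shown alone.

Measured compounds:
compound 1 `COc1cc(-c2cc(/C=C/C(=O)c3ccc(Cl)c(Cl)c3)[nH]n2)cc(OC)c1OC` — 46%
compound 2 `COc1ccc(C(=O)/C=C/c2cc(-c3cc(OC)c(OC)c(OC)c3)n[nH]2)cc1OC` — 100%
compound 3 `COc1ccc(C(=O)/C=C/c2cc(-c3cc(OC)c(OC)c(OC)c3)n[nH]2)cc1` — -29%

In a functional assay on TK-10 cells (Homo sapiens) for cytotoxicity, read by sulforhodamine B assay, with a stated time of 48 h, tested at 10 uM (on this read-out higher numbers stand for a weaker effect at the one concentration tested and lower numbers for a stronger effect), compound 3 gives -29% and stands lowest of the three numbers, the strongest effect at the single concentration; its nearest neighbour is compound 1, which lies higher by a number 75 percentage points lower from compound 1 to compound 3 (beyond the scatter) in reverse, and compound 2 lies furthest, as a number 129 percentage points lower from compound 2 to compound 3 (beyond the scatter) shows.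

Compound 4 `COc1cc(-c2cc(/C=C/C(=O)c3ccc(F)c(F)c3)[nH]n2)cc(OC)c1OC` is not yet measured. It differs from compound 3 by 3,4-difluorophenyl in place of 4-methoxyphenyl on a carbonyl carbon.

The step that bears on this change is a number 75 percentage points lower from compound 1 to compound 3 (beyond the scatter), where the 3,4-dichlorophenyl of compound 1 was replaced by the 4-methoxyphenyl of compound 3 and the number fell by a large margin. Compound 4 runs that exchange the other way, with a 3,4-difluorophenyl entering; a second halogenated ring is expected to move the number back toward compound 1, by an amount comparable to that step. The step of a number 54 percentage points higher from compound 1 to compound 2 (beyond the scatter) concerns a 3,4-dimethoxyphenyl and points the other way, so the gain is expected to be partial rather than complete.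

Compound 4 is therefore expected to give 40%, within -10% to 90%, which means an expected rise of a number 69 percentage points higher from compound 3 to compound 4 (beyond the scatter).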

Compound 4, a percentage reported as activity, at one concentration (the size of the read-out at that concentration, not a potency): -13%
Estimate against measurement, compound 4: 53 percentage points above; the whole stated range lies above it.
By their numbers in this assay, from the lowest: compound 3; then compound 4; then compound 1; then compound 2.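

In this assay the two dihalophenyl groups on the carbonyl carbon do not behave alike (a number 59 percentage points lower from compound 1 to compound 4 (beyond the scatter)), so the identity of the halogen at this place carries a large part of the read-out. The 3,4-difluorophenyl group instead lies close to 4-methoxyphenyl (a number 16 percentage points higher from compound 3 to compound 4 (beyond the scatter)) and far from 3,4-dimethoxyphenyl (a number 113 percentage points lower from compound 2 to compound 4 (beyond the scatter)), so neither halogen nor methoxy substitution as such sorts the four compounds, with compound 1 and compound 4 going against a halogen rule and compound 2 and compound 3 against a methoxy rule. Nothing available explains these differences.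

Open, going by these compounds, is whether a 4-fluorophenyl or a 4-(dimethylamino)phenyl group on the carbonyl carbon would fall with compound 4 or with compound 1. The single-concentration read-out also gives no potency for any of the four.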